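Methoxy for nitro on a cinnamic acid triazole series

The compounds below may be only part of what the source reports. "The series", "measured", "known", "first", "only" and "open" are said of these compounds alone.

Compound 1, with the structure `COc1ccc(/C=C\C(=O)O)c(OCc2cn(-c3cccc([N+](=O)[O-])c3)nn2)c1CC=C(C)C`, is the starting point of this step. It was tested in a functional assay on A549 cells (Homo sapiens) for cytotoxicity, read by MTT assay, with a stated time of 24 h (on this read-out lower numbers stand for stronger inhibition and higher numbers for weaker inhibition), but for compound 1 the entry reads "not determined" (no result reported); the same is true of compound 2, with the structure `COc1ccc(/C=C\C(=O)O)c(OCc2cn(-c3ccc(NC(C)=O)cc3)nn2)c1CC=C(C)C`, for which compound 2 likewise shows "not determined" (no result reported). Among the compounds with values here, the only number in the set belongs to compound 3, with the structure `COc1ccc(/C=C\C(=O)O)c(OCc2cn(-c3ccc(NC(=O)c4ccccc4)cc3)nn2)c1CC=C(C)C`: in this assay compound 3 gives 42700 nM, a weak effect. Compound 1 therefore cannot be placed on the numbers shown; it stands only as a structure beside one measured relative.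

The move to compound 4, with the structure `COc1cccc(-n2cc(COc3c(/C=C\C(=O)O)ccc(OC)c3CC=C(C)C)nn2)c1`, is a single change: methoxy in place of nitro on an aromatic carbon.

Within the data shown here, no measured pair shows what such a change does in this assay, so the size of the step from compound 1 to compound 4 is unknown; with only compound 3 at 42700 nM as a guide, a step no larger than the usual scatter, in either direction, is the plainest expectation. Compound 4 is estimated at 40000 nM, with a range from 15000 nM to 120000 nM.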

Compound 4, half-maximal inhibitory concentration: 42700 nM
Compound 4: the middle estimate sits 1.1-fold (0.03 log units) below what was measured; low and high end bracket the measured number.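

Within the data shown here, compound 4 adds no new step, as compound 1 has no single number to set it against. Nothing shown here bears on a cause for this result. The compounds shown leave open what replacing 3-nitrophenyl with 3-methoxyphenyl does in this assay.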